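The compounds below may be only part of what the source reports. "The series", "measured", "known", "first", "only" and "open" are said of these compounds alone.

In a functional assay on A549 cells (Homo sapiens), read by sulforhodamine B assay, with a stated time of 5 days (a lower number here means a stronger inhibitor of growth, a higher number a weaker inhibitor of growth), compound 1 `OC[C@H]1O[C@@H](n2cc(F)c3c(-c4ccccc4)ncnc32)[C@H](O)[C@@H]1O` gives > 10000 nM, which is a limit of the assay. Among the compounds with values here, compound 2 `OC[C@H]1O[C@@H](n2cc(Cl)c3c(-c4ccccc4)ncnc32)[C@H](O)[C@@H]1O` gives 2500 nM, the only true number so far. Compound 3 `OC[C@H]1O[C@@H](n2cc(Cl)c3c(-c4cccs4)ncnc32)[C@H](O)[C@@H]1O` carries thiophen-2-yl in place of phenyl on an aromatic carbon. Within the data shown here, the one measured step, an at least 4.0-fold lower number from compound 1 to compound 2 (0.60 log units; beyond the scatter), lies beyond the scatter but concerns the halogen, and no measured step changes the aryl group. It therefore bears only indirectly, as a sign that one small change can move this assay. A step of similar or somewhat larger size towards a lower number is expected: a 5.0-fold lower number from compound 2 to compound 3 (0.70 log units; beyond the scatter). The estimate for compound 3 is 500 nM, with an expected range of 50 nM to 3000 nM.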

Compound 3, concentration for 50% growth inhibition: 380 nM
Estimate against measurement, compound 3: 1.3-fold (0.12 log units) above; the range from low to high includes it.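

In this assay the aryl group now proves to matter as well as the halogen: with chloro held, thiophen-2-yl in place of phenyl on the aromatic carbon next to the ring nitrogen gives a 6.6-fold lower number from compound 2 to compound 3 (0.82 log units; beyond the scatter). A five-membered aromatic ring with 1 hetero atom is therefore accepted at this position, and the number falls further than with phenyl. Nothing shown gives a reason for this step.

Whether the sulfur or the smaller ring accounts for the step remains open. Also open, on these data alone, is how furan-2-yl or an amine on this carbon would read.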